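The compounds below may be only part of what the source reports. "The series", "measured", "known", "first", "only" and "open" are said of these compounds alone.

Measured so far in an ADME assay on MT4 cells (Homo sapiens) for cytotoxicity, read by MTT assay, with a stated time of 5 days (a higher number here means that more compound is tolerated, a lower number that less compound is tolerated), each value a limit of the assay and not a number:

- compound 1 `CCCNc1cc(Oc2c(OC)cc3cc(C#N)ccc3c2OC)nc(Nc2ccc(C#N)cc2)n1` gives > 125000 nM as its limit
- compound 2 `CCC(C)Nc1cc(Oc2c(OC)cc3cc(C#N)ccc3c2OC)nc(Nc2ccc(C#N)cc2)n1` gives > 125000 nM as its limit
- compound 3 `CCCC(CCC)Nc1cc(Oc2c(OC)cc3cc(C#N)ccc3c2OC)nc(Nc2ccc(C#N)cc2)n1` gives > 125000 nM as its limit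

Compound 3 therefore has no exact number and stands with the other two compounds (the limit of > 125000 nM in this assay, at which 3 of the 3 values shown sit). The next compound is compound 4 `COc1cc2cc(C#N)ccc2c(OC)c1Oc1cc(NC2CCCCC2)nc(Nc2ccc(C#N)cc2)n1`, with cyclohexyl in place of 1-propylbutyl on a nitrogen on an aromatic ring. The open chain gives way to a ring of similar count.

Going by the values given here, three measured steps bear on this change, all on the group at that nitrogen: (a step that the two limits leave unreadable from compound 1 to compound 2), (a step that the two limits leave unreadable from compound 1 to compound 3) and (a step that the two limits leave unreadable from compound 2 to compound 3). None has a readable size, so no measured size can be carried over. With no sign of a shift in either direction, the expected step is (a number no higher from compound 3 to compound 4 (the limit leaves the size open)), nothing beyond the usual scatter in this assay and quite possibly another limit. Compound 4 is estimated at (125000 nM), with an expected range (from 60000 nM to 250000 nM).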

Compound 4, half-maximal cytotoxic concentration: > 125000 nM
Compound 4 ended at the assay's limit; the forecaster's own chance of this, stated with the estimate: 85%; the middle value lies on the limit itself.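

Compound 4 gives only a limit of the assay, as do compound 1, compound 2 and compound 3, so no step among these four compounds can be read: the limit of > 125000 nM in this assay, at which 4 of the 4 values shown sit. The compounds shown leave open whether changing the group on that nitrogen shifts the tolerated concentration at all in this assay.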